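A few compounds are considered here, and "the series" means these few. Any claim that something is new, unique, unknown or untested is made for them only; others in the source may bear on it.

Measured compounds in a functional assay on CHO-K1 cells for agonist activity at Glucose-dependent insulinotropic receptor (Homo sapiens), read by a luciferase reporter, with a stated time of 5 h; a lower number here means that less compound is needed, a higher number that more compound is needed for the effect:
compound 1 `CCCS(=O)(=O)N1CCN(c2ccc(OCC3CCN(C(=O)OC(C)C)CC3)cn2)CC1` gives 300 nM;
compound 2 `CCCCS(=O)(=O)N1CCN(c2ccc(OCC3CCN(C(=O)OC(C)C)CC3)cn2)CC1` gives 100 nM;
compound 3 `CC(C)OC(=O)N1CCC(COc2ccc(N3CCN(S(=O)(=O)C4CCCCC4)CC3)nc2)CC1` gives 200 nM.

Compound 1 stands with the highest of the three numbers in this assay. Its nearest neighbour is compound 3, and that gap is a 1.5-fold lower number from compound 1 to compound 3 (0.18 log units; within the scatter), which lies within the scatter. The furthest is compound 2, reached by a 3.0-fold lower number from compound 1 to compound 2 (0.48 log units; beyond the scatter), a step beyond the scatter. The remaining pair, compound 2 to compound 3, differs by a 2.0-fold higher number from compound 2 to compound 3 (0.30 log units; within the scatter), again within the scatter. All three of these measured steps change the group on the sulfonyl sulfur and leave the rest of the shared core untouched.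

Compound 4 `CCCS(=O)(=O)N1CCN(c2ccc(OCC3CCN(C(=O)NC(C)(C)C)CC3)cn2)CC1` is not yet measured. It differs from compound 1 by (tert-butyl)amino in place of isopropoxy on a carbonyl carbon; cut one bond further out, the change reads isopropoxycarbonyl to (tert-butyl)carbamoyl. Within the data shown here, none of the measured steps touches this end of the molecule, so no measured step bears on it, and the data give no direction for this change. With nothing pointing either way, the expected step is none beyond the scatter, that is no change at the digits printed from compound 1 to compound 4 (within the scatter), though with a wide range. Compound 4 is therefore estimated at 300 nM in this assay, with a range from 80 nM to 1200 nM.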

Compound 4, half-maximal effective concentration: 800 nM
Beside the measured number, compound 4's estimate is 2.7-fold (0.43 log units) below it; measured number inside the range.
By their numbers in this assay, from the lowest: compounds 2, 3 and 1 (each within the scatter of the next, the first and the last beyond it); then compound 4.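

Among these compounds, the result is the first reading at this end of the molecule: in this assay, (tert-butyl)amino in place of isopropoxy on a carbonyl carbon gives a 2.7-fold higher number from compound 1 to compound 4 (0.43 log units; beyond the scatter), so the number responds to a change here as well as to changes on the sulfonyl sulfur. Among the compounds shown here, the direction is opposite to that of the one step beyond the scatter at the sulfonyl end, a 3.0-fold lower number from compound 1 to compound 2 (0.48 log units; beyond the scatter), although this single swap changes several things at once: a nitrogen replaces an oxygen, the entering group has more heavy atoms, and it carries a hydrogen-bond donor that isopropoxy lacks. Nothing available here explains the higher number or assigns it to any one of these differences.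

The compounds shown leave open whether the rise follows the nitrogen or the tert-butyl group, a question that isopropylamino or tert-butoxy on the same carbonyl carbon would address. They also leave open whether (tert-butyl)amino would shift the number in the same way with butyl or cyclohexyl on the sulfonyl sulfur, as in compound 2 and compound 3.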